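Acetoxymethyl enone series: aryl replacing cyclohexyl on the chain

The source may report more compounds than this note shows. Statements on the series, on what has been measured and on what is new or still open speak of the compounds shown alone.

Measured so far in a functional assay on T47D cells (Homo sapiens) for inhibition, read by sulforhodamine B assay, with a stated time of 48 h; a higher number here means a weaker inhibitor of growth, a lower number a stronger inhibitor of growth:
compound 1 `CC(=O)OC/C(=C\C1CCCCC1)C(=O)c1ccccc1` gives 22000 nM
compound 2 `CCC(/C=C(\COC(C)=O)C(=O)c1ccccc1)CC` gives 89000 nM
compound 3 `CC(=O)OC/C(=C\C1CCCCC1)C(=O)c1ccc(Cl)cc1` gives 18000 nM

Compound 3 holds the lowest number of the three, but its gap to compound 1 lies within the scatter; only compound 2 stands clearly apart. Compound 4 `CC(=O)OC/C(=C\c1ccc(Cl)cc1Cl)C(=O)c1ccc(Cl)cc1` differs from compound 3 by 2,4-dichlorophenyl in place of cyclohexyl on a double-bonded chain carbon bound to a double-bonded chain carbon. Within the data shown here, the one measured step at that place is a 4.0-fold higher number from compound 1 to compound 2 (0.61 log units; beyond the scatter), so this position does respond to change; the step of a 1.2-fold lower number from compound 1 to compound 3 (0.09 log units; within the scatter) lies elsewhere and was within the scatter. No aryl group at this place has been measured, so direction is open. For compound 4 a step of a 1.5-fold lower number from compound 3 to compound 4 (0.18 log units; within the scatter) is expected, a number near 12000 nM with a range from 3000 nM to 45000 nM.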

Compound 4, concentration for 50% growth inhibition: 5200 nM
Compound 4: middle estimate off by 2.3-fold (0.36 log units), on the high side; the range from low to high includes it.
By their numbers in this assay, from the lowest: compound 4; then compounds 3 and 1 (each within the scatter of the next); then compound 2.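

In this assay, 2,4-dichlorophenyl in place of cyclohexyl on a double-bonded chain carbon bound to a double-bonded chain carbon gives a 3.5-fold lower number from compound 3 to compound 4 (0.54 log units; beyond the scatter), so an aryl group at this place can lower the number. The earlier step at this place, with pentan-3-yl in place of cyclohexyl, ran the other way: a 4.0-fold higher number from compound 1 to compound 2 (0.61 log units; beyond the scatter). No measurement on hand explains this shift. On these data alone, whether the aromatic ring alone or its two chloro groups carry the step remains open. Plain phenyl or a pyridine ring at this place would separate these.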